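A few compounds are considered here, and "the series" means these few. Any claim that something is new, unique, unknown or untested is made for them only; others in the source may bear on it.

Series notes. In an ADME assay on HEK293 cells (Homo sapiens) for cytotoxicity, read by resazurin assay, with a stated time of 48 h (a higher number here means that more compound is tolerated, a lower number that less compound is tolerated), compound 1 `COc1ccc(S(=O)(=O)Nc2ccc3oc(-c4ccc(NS(=O)(=O)c5cc(F)ccc5OC)cc4)nc3c2)cc1` gives 24000 nM. Compound 2 `O=S(=O)(Nc1ccc(-c2nc3cc(NS(=O)(=O)c4ccc(Br)cc4)ccc3o2)cc1)c1ccc(Br)cc1` gives 22000 nM in this assay, and compound 3 `O=C(Nc1ccc(Sc2nc3ccccc3s2)cc1)c1cccc(Br)c1O` gives 33000 nM in this assay. On these three numbers compound 1 stands second highest, yet its gaps to compound 2 and to compound 3 both lie within the scatter, so no order among the three can be read. Compound 4 `COc1ccc(S(=O)(=O)Nc2ccc(-c3nc4cc(NS(=O)(=O)c5ccc(OC)cc5)ccc4o3)cc2)cc1` is not yet measured in this assay. It differs from compound 1 by 4-methoxyphenyl in place of 5-fluoro-2-methoxyphenyl on a sulfonyl sulfur. For the measured compounds named here, with no measured step of this kind to lean on, the expectation is for a step from compound 1 to compound 4 of a 1.0-fold higher number from compound 1 to compound 4 (0.02 log units; within the scatter), that is, none beyond the scatter. Compound 4 is therefore estimated at 25000 nM in this assay, with a range from 12000 nM to 50000 nM.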

Compound 4, half-maximal cytotoxic concentration: 48000 nM
For compound 4 the middle estimate is 1.9-fold (0.28 log units) below the measured one; measured number inside the range.
By their numbers in this assay, from the lowest: compounds 2, 1, 3 and 4 (each within the scatter of the next, the first and the last beyond it).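

For the compounds shown here, this is the first step that differs in one place: in this assay, 4-methoxyphenyl in place of 5-fluoro-2-methoxyphenyl on a sulfonyl sulfur gives a 2.0-fold higher number from compound 1 to compound 4 (0.30 log units; within the scatter). The step stays inside the scatter, so at this position the exchange of these two groups gives no readable change in the tolerated concentration. No measurement here bears on a cause for this step. As far as these compounds go, it remains open whether a piperidine or a carboxylic acid on the aryl ring at this sulfonyl sulfur would shift the number beyond the scatter.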